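Bromo in place of methoxy on the 4-methoxybenzyl group

The source may report more compounds than this note shows. Statements on the series, on what has been measured and on what is new or still open speak of the compounds shown alone.

In a functional assay on MIA PaCa-2 cells (Homo sapiens) for inhibition, read by MTT assay, with a stated time of 48 h, tested at 10 uM (on this read-out higher numbers stand for more inhibition of growth at the one concentration tested and lower numbers for less inhibition of growth), compound 1 (`Cc1cc(=O)c2c(O)cc(OCc3ccccc3)c([C@H]3CCN(C)C[C@H]3O)c2o1`) gives 14% and compound 2 (`COc1ccc(COc2cc(O)c3c(=O)cc(C)oc3c2[C@H]2CCN(C)C[C@H]2O)cc1`) gives 15% within the scatter of compound 1. Compound 3 (`Cc1cc(=O)c2c(O)cc(OCc3ccc(Br)cc3)c([C@H]3CCN(C)C[C@H]3O)c2o1`) has bromo in place of methoxy on an aromatic carbon, para to a large group (bromo in place of methoxy on an aromatic carbon). For the measured compounds named here, the only measured step (a number 1 percentage points higher from compound 1 to compound 2 (within the scatter)) places methoxy on that same carbon in place of hydrogen and stays within the scatter. Going by the values given here, no bromo compound has been measured yet. The expected step (a number 1 percentage points higher from compound 2 to compound 3 (within the scatter)) is none beyond the scatter. For compound 3 the estimated value in this assay is 16% with an expected range of 5% to 30% for now.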

Compound 3, percent growth inhibition at one concentration: 13%
Compound 3: the middle estimate sits 3 percentage points above what was measured; the range from low to high includes it.
By their numbers in this assay, from the lowest: compounds 3, 1 and 2 (each within the scatter of the next).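

In this assay, bromo in place of methoxy on the aromatic carbon para to a large group gives a number 2 percentage points lower from compound 2 to compound 3 (within the scatter), and bromo in place of hydrogen there gives a number 1 percentage points lower from compound 1 to compound 3 (within the scatter). Hydrogen, methoxy and bromo on this carbon are thus not told apart by this read-out, and a halogen changes that no more than methoxy did. Nothing at hand offers an explanation for this result. As far as these compounds go, whether an amine or a carboxylic acid on this carbon would give a step beyond the scatter remains open. So does whether any change on the shared core would do so.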